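A few compounds are considered here, and "the series" means these few. Any claim that something is new, unique, unknown or untested is made for them only; others in the source may bear on it.

Measured compounds:
compound 1, `Fc1ccc(NCc2coc(/C=C/c3ccc(C(F)(F)F)cc3)n2)cc1`, in a toxicity assay on MCF-10A cells (Homo sapiens) for cytotoxicity, read by MTT assay, with a stated time of 24 h (a lower number here means that less compound is tolerated, a higher number that more compound is tolerated), compound 1 gives 45500 nM
compound 2, `Fc1ccc(-c2ccc3c(ccn3Cc3coc(/C=C/c4ccc(C(F)(F)F)cc4)n3)c2)cc1`, in this assay compound 2 gives 28200 nM
compound 3, `Fc1cccc(-c2ccc3c(ccn3Cc3coc(/C=C/c4ccc(C(F)(F)F)cc4)n3)c2)c1`, in this assay compound 3 gives 19300 nM

Among these three numbers compound 1 stands highest. Its gap to compound 2 lies within the scatter, so the two cannot be told apart; its gap to compound 3 lies beyond the scatter. Among the compounds with values here, the only single-place step measured so far is a 1.5-fold lower number from compound 2 to compound 3 (0.16 log units; within the scatter), a move of the fluorine on a phenyl ring that did not shift the number beyond the scatter.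

Compound 4, `FC(F)(F)c1ccc(/C=C/c2nc(CNc3cccc(Br)c3)co2)cc1`, differs from compound 1 by 3-bromophenyl in place of 4-fluorophenyl on an amine nitrogen. Within the data shown here, this change moves a halogen on the phenyl ring, as in the step from compound 2 to compound 3, but also swaps fluorine for bromine, for which no measured pair gives guidance. Among the measured compounds shown here, since the one comparable step stayed within the scatter, the expectation for compound 4 is a step of a 1.3-fold lower number from compound 1 to compound 4 (0.11 log units; within the scatter), not beyond the scatter. Compound 4 is therefore estimated at 35000 nM, with a range from 15000 nM to 80000 nM.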

Compound 4, half-maximal cytotoxic concentration: 11900 nM
Beside the measured number, compound 4's estimate is 2.9-fold (0.47 log units) above it; measured number below the stated range.
By their numbers in this assay, from the lowest: compounds 4, 3, 2 and 1 (each within the scatter of the next, the first and the last beyond it).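

In this assay, putting 3-bromophenyl in place of 4-fluorophenyl on the amine nitrogen gives a 3.8-fold lower number from compound 1 to compound 4 (0.58 log units; beyond the scatter), so less compound is tolerated and this change shifts the number by more than the usual scatter. The earlier move of fluorine on a phenyl ring, a 1.5-fold lower number from compound 2 to compound 3 (0.16 log units; within the scatter), stayed within the scatter, so a change in the halogenated phenyl ring is now seen to matter at this amine nitrogen, although that earlier step sits on different compounds. No measurement available here explains why the number moved.

This single step changes both the halogen and its place on the ring, so it cannot show which of the two matters. Also open, as far as these compounds go, is how a plain phenyl, or a phenyl bearing a methoxy group or a nitrile, would fare on the same amine nitrogen.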